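From Piperidin-1-yl to Pyrrolidin-1-yl on a Shared Core

The source may hold more compounds than are shown below. What is called first, only, known or untested is meant among the compounds shown, and "the series" means these compounds.

Measured in an ADME assay on L6 cells (Rattus norvegicus) for cytotoxicity; on this read-out lower numbers stand for stronger inhibition and higher numbers for weaker inhibition:
compound 1 `CN1CCN(CCC(=O)OC2CC3(N4CCCC4)CC(c4ccccc4)C2C(c2ccccc2)C3)CC1`: 21300 nM
compound 2 `CN1CCN(CCCC(=O)OC2CC3(N4CCCCC4)CC(c4ccccc4)C2C(c2ccccc2)C3)CC1`: 22300 nM
compound 3 `O=C(CN1CCCCC1)OC1CC2(N3CCCCC3)CC(c3ccccc3)C1C(c1ccccc1)C2`: 60400 nM

Among these three, compound 2 sits within the scatter of compound 1, while compound 3 gives a clearly higher number. The next compound to be read, compound 4 `CN1CCN(CCCC(=O)OC2CC3(N4CCCC4)CC(c4ccccc4)C2C(c2ccccc2)C3)CC1`, departs from compound 2 in one place: pyrrolidin-1-yl in place of piperidin-1-yl on a saturated ring carbon, with pyrrolidin-1-yl in place of piperidin-1-yl on a saturated ring carbon.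

For the measured compounds named here, no measured step isolates this exchange. Going by the values given here, the only single-place step available, a 2.7-fold higher number from compound 2 to compound 3 (0.43 log units; beyond the scatter), is modest, but it concerns a different site, a saturated chain carbon bound to a carbonyl carbon, and so says little here. Compound 1 offers the closest hint, since it already carries pyrrolidin-1-yl, although it also differs from compound 2 in its side chain. Even with both differences, compound 1 at 21300 nM stays within the scatter of compound 2. In this assay, therefore, no step beyond the scatter is expected, and no direction can be favoured. The estimated change is a 1.0-fold lower number from compound 2 to compound 4 (0.01 log units; within the scatter) and would be unremarkable. Compound 4 is expected at about 22000 nM in this read-out. Its estimated range runs from 11000 nM to 43000 nM as a plausible span.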

Compound 4, half-maximal inhibitory concentration: 10200 nM
Compound 4: middle estimate off by 2.2-fold (0.33 log units), on the high side; measured number outside the range, below it.
By their numbers in this assay, from the lowest: compound 4; then compounds 1 and 2 (each within the scatter of the next); then compound 3.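

In this assay, the exchange of piperidin-1-yl for pyrrolidin-1-yl on the saturated ring carbon of the shared core can now be read on its own, with the side chain held constant, as a 2.2-fold lower number from compound 2 to compound 4 (0.34 log units; beyond the scatter) and a step beyond the usual scatter. The side chain also registers once pyrrolidin-1-yl is in place: (4-methylpiperazin-1-yl)methyl in place of 4-methylpiperazin-1-yl, on a saturated chain carbon two bonds along the chain from a carbonyl carbon, gives a 2.1-fold lower number from compound 1 to compound 4 (0.32 log units; beyond the scatter) as a step of modest size. Compound 4 thus has the lowest number of the set, reached from either neighbour by a single change, and nothing at hand gives a reason for either step.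

Going by these compounds, whether pyrrolidin-1-yl would lower the number in the same way alongside the shorter piperidin-1-yl side chain of compound 3 remains open. So does the behaviour of other amines at the same ring carbon, such as morpholin-4-yl, azetidin-1-yl or an open-chain dimethylamino group, and of a still longer chain leading to the 4-methylpiperazin-1-yl group.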